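Fused quinone series: methylsulfanyl in place of methylamino

The compounds below may be only part of what the source reports. "The series", "measured", "known", "first", "only" and "open" are said of these compounds alone.

Measured compounds, all in a functional assay on cells (Neutrophil, Homo sapiens) for inhibition, read by WST assay, with a stated time of 20 min; a higher number here means a weaker inhibitor, a lower number a stronger inhibitor:
Compound 1 `CNC1=C(SC)C(=O)c2ncccc2C1=O` gives > 200000 nM, a limit of the assay.
Compound 2 `CSC1=C(N)C(=O)c2cccnc2C1=O` gives > 150000 nM, a limit of the assay.
Compound 3 `CNC1=C(SC)C(=O)c2cccnc2C1=O` gives > 200000 nM, a limit of the assay.

Compound 3 stands at a limit, as do the other two measured compounds: the limit of > 200000 nM in this assay, at which 2 of the 3 values shown sit, and the limit of > 150000 nM in this assay, at which 1 of the 3 values shown sits, cover everything shown so far. For the measured compounds named here, the only one-place step among measured compounds is a step that the two limits leave unreadable from compound 1 to compound 2, and it cannot be read because both ends are limits. Compounds 1 and 3 share the same limit; compound 2 sits at a different limit, which shows nothing about order between them.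

Compound 4 `CSC1=C(SC)C(=O)c2ncccc2C1=O` differs from compound 3 by methylsulfanyl in place of methylamino on a double-bonded ring carbon. Going by the values given here, no measured step bears on this change, since every value is a limit and no readable step exists anywhere. The expected step of a number no higher from compound 3 to compound 4 (the limit leaves the size open) is therefore none beyond the scatter, with compound 4 most likely returned as a limit again. Compound 4 is estimated at 200000 nM, with a range from 80000 nM to 500000 nM.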

Compound 4, half-maximal inhibitory concentration: 110 nM
Compound 4: the middle estimate sits 1800-fold (3.26 log units) above what was measured, outside the stated range (below it).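

In this assay, the double-bonded ring carbon gives the first readable response in the series: methylsulfanyl in place of methylamino gives an at least 1800-fold lower number from compound 3 to compound 4 (3.25 log units; beyond the scatter) and an at least 1800-fold lower number from compound 1 to compound 4 (3.25 log units; beyond the scatter), and methylsulfanyl in place of amino gives an at least 1300-fold lower number from compound 2 to compound 4 (3.13 log units; beyond the scatter). Compound 4 gives 110 nM, the only readable number among the compounds shown. All three steps start from a limit, so each fixes only the smallest possible size of the change. No measured property shown here bears on why the number falls so far.

The step from compound 1 to compound 2 cannot be read, so amino and methylamino remain unordered. From the compounds shown here alone, whether ethylsulfanyl or methoxy on this carbon would keep a number close to that of compound 4 remains open.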